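A few compounds are considered here, and "the series" means these few. Any claim that something is new, unique, unknown or untested is made for them only; others in the source may bear on it.

Measured so far in a functional assay for inhibition, read by spectrophotometry, with a stated time of 20 min, tested at 4 mg/mL; on this read-out lower numbers stand for a weaker effect and higher numbers for a stronger effect at the one concentration tested:
- compound 1 `CCC(C)C(C(=O)Nc1ccc(C(C)=O)cc1)N(C(=O)c1ccccc1)S(=O)(=O)c1ccc(C)cc1` gives 41.1%
- compound 2 `CC(=O)c1ccc(NC(=O)C2CC(O)CN2S(=O)(=O)c2ccc(C)cc2)cc1` gives 12.9%
- compound 3 `CCC(C)C(C(=O)Nc1ccc(C(C)=O)cc1)N(C(=O)c1ccccc1)S(=O)(=O)c1ccc([N+](=O)[O-])cc1` gives 48.4%

Compound 2 stands lowest of the three numbers; its nearest neighbour is compound 1, and compound 3 stands furthest from it, both gaps beyond the scatter. The unmeasured compound 4 `CC(=O)c1ccc(NC(=O)C2CC(O)CN2S(=O)(=O)c2ccc([N+](=O)[O-])cc2)cc1` differs from compound 2 by nitro in place of methyl on an aromatic carbon. Going by the values given here, the one measured step of the same kind, on the shared core of compound 1, is a number 7.3 percentage points higher from compound 1 to compound 3 (within the scatter), a step within the scatter. Carried over to the core of compound 2, the change is therefore expected to give at most a small rise, a number 5.1 percentage points higher from compound 2 to compound 4 (within the scatter), with no step beyond the scatter assured. For compound 4 the expected value in this assay is 18%, estimated between 5% and 34%.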

Compound 4, a percentage reported as inhibition, at one concentration (the size of the read-out at that concentration, not a potency): 60.1%
For compound 4 the middle estimate is 42.1 percentage points below the measured one; measured number outside the range, above it.
By their numbers in this assay, from the lowest: compound 2; then compounds 1 and 3 (each within the scatter of the next); then compound 4.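

On the core of compound 2, 4-methylphenyl to 4-nitrophenyl in this assay gives a number 47.2 percentage points higher from compound 2 to compound 4 (beyond the scatter), so this position is not silent on every core. The step measured on the core of compound 1 therefore does not carry over, and the size of the change depends on the core that bears it: the same change on two cores in this assay, a number 7.3 percentage points higher (within the scatter) from compound 1 to compound 3 and a number 47.2 percentage points higher (beyond the scatter) from compound 2 to compound 4, 39.9 percentage points apart, beyond the scatter of two such steps

Open: whether an amine or a carboxylic acid at this place on the core of compound 2 would give a step of like size. From the compounds shown here alone, also open: which part of the two cores sets the gap between the steps.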